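The source may report more compounds than this note shows. Statements on the series, on what has been measured and on what is new or still open speak of the compounds shown alone.

Three compounds share one core. In an in vitro assay on HEK ts201 cells for negative allosteric modulation of Neuronal acetylcholine receptor; alpha4/beta2 (Homo sapiens), read by fluorescence and calcium flux, with a stated time of 1.5 s (a lower number here means a stronger inhibitor, a higher number a weaker inhibitor), compound 1 `COc1ccc(NC(=O)CN2CCN(S(=O)(=O)c3ccc(F)cc3)CC2)cc1` gives 21100 nM; compound 2 `O=C(CN1CCN(S(=O)(=O)c2ccc(F)cc2)CC1)Nc1ccccc1` gives 14900 nM; compound 3 `O=C(CN1CCN(S(=O)(=O)c2ccccc2F)CC1)Nc1ccccc1F` gives 8000 nM. Compound 3 shows the lowest of the three numbers, with compound 2 within the usual scatter of it and compound 1 beyond it. Compound 4 `O=C(CN1CCN(S(=O)(=O)c2ccccc2)CC1)Nc1ccccc1F` differs from compound 3 by hydrogen in place of fluoro on an aromatic carbon. Within the data shown here, the only single-point change measured so far, a 1.4-fold lower number from compound 1 to compound 2 (0.15 log units; within the scatter), was small. Compound 2 and compound 3 differ in two places at once, so their numbers say nothing about one fluoro alone. Removing one fluoro is therefore expected to move the number little, and compound 4 is estimated at 10000 nM, between 4000 nM and 25000 nM. The expected step is a 1.3-fold higher number from compound 3 to compound 4 (0.10 log units; within the scatter).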

Compound 4, half-maximal inhibitory concentration: 4100 nM
The estimate for compound 4 lay 2.4-fold (0.39 log units) above the measured number; the measured number falls inside the stated range.
By their numbers in this assay, from the lowest: compounds 4, 3, 2 and 1 (each within the scatter of the next, the first and the last beyond it).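

In this assay, among these compounds, the change from 2-fluorophenyl to phenyl gives a 2.0-fold lower number from compound 3 to compound 4 (0.29 log units; within the scatter), the first single-place reading at this position ortho to a large group. The step stays within the usual scatter, so the number does not depend on this fluoro. Nothing available explains the step. Still open, from the compounds shown here alone, is whether an amine, a carboxylic acid or a nitrile at this same position would move the number beyond the scatter. Also open, going by these compounds, is what removing the remaining fluoro of compound 4 would do.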